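From 4-bromobenzyl to benzyl in a growth test

The compounds below may be only part of what the source reports. "The series", "measured", "known", "first", "only" and "open" are said of these compounds alone.

Values measured in a functional assay on PC-3 cells (Homo sapiens) for inhibition, read by sulforhodamine B assay, with a stated time of 48 h (on this read-out lower numbers stand for stronger inhibition of growth and higher numbers for weaker inhibition of growth), for three compounds:
- Compound 1 `Ic1ccc(Cn2cc(CCCOc3cccc4cccnc34)nn2)cc1` gives 24.7 ug/mL as its value
- Compound 2 `Brc1ccc(Cn2cc(CCCOc3cccc4cccnc34)nn2)cc1` gives 8.4 ug/mL as its value
- Compound 3 `Clc1ccc(Br)cc1Cn1cc(CCCOc2cccc3cccnc23)nn1` gives 8.2 ug/mL as its value

Compound 2 stands level with compound 3, since a 1.0-fold lower number from compound 2 to compound 3 (0.01 log units; within the scatter) lies within the scatter. Both sit clearly under compound 1, with a 2.9-fold lower number from compound 1 to compound 2 (0.47 log units; beyond the scatter) and a 3.0-fold lower number from compound 1 to compound 3 (0.48 log units; beyond the scatter) as modest steps beyond the scatter.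

The next compound is compound 4 `c1ccc(Cn2cc(CCCOc3cccc4cccnc34)nn2)cc1`, in which hydrogen takes the place of bromo on an aromatic carbon, para to a large group, turning 4-bromophenyl into phenyl (hydrogen in place of bromo on an aromatic carbon). Among the measured compounds shown here, no measured compound shows this change directly. The nearest guide is the exchange of iodo for bromo at that place, the modest 2.9-fold lower number from compound 1 to compound 2 (0.47 log units; beyond the scatter) step, which suggests that a change here can shift the number by a modest amount. Its direction for hydrogen is not shown by the data.

The expected change is a 1.7-fold higher number from compound 2 to compound 4 (0.22 log units; within the scatter) and it is only a weak lean toward a higher number. Compound 4 is estimated at 14 ug/mL with 6 ug/mL to 35 ug/mL as the expected range.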

Compound 4, concentration for 50% growth inhibition: 16.8 ug/mL
Estimate against measurement, compound 4: 1.2-fold (0.08 log units) below; the measured number falls inside the stated range.
By their numbers in this assay, from the lowest: compounds 3, 2, 4 and 1 (each within the scatter of the next, the first and the last beyond it).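

In this assay, taking the halogen away altogether gives a 2.0-fold higher number from compound 2 to compound 4 (0.30 log units; within the scatter) and a 1.5-fold lower number from compound 1 to compound 4 (0.17 log units; within the scatter), so hydrogen at this place, para to a large group, cannot be told apart from either bromo or iodo, even though the earlier step showed bromo and iodo apart. Among the compounds shown here, the one step here that clears the scatter is a 2.0-fold higher number from compound 3 to compound 4 (0.31 log units; beyond the scatter), and it is modest. No measured evidence explains these differences.

The compounds shown leave open whether a non-halogen group at this place, such as methoxy, an amine or a carboxylic acid, would give a number outside the span seen so far. They also leave open how a longer chain in the linker of the shared core would change the number.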